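The compounds below may be only part of what the source reports. "The series", "measured", "known", "first", "only" and "open" are said of these compounds alone.

Compound 1 `CNC(=S)NCCC(O)c1ccccc1N`: 20.7%
Compound 2 `CCNC(=O)NCCC(O)c1ccccc1N`: 18.3%

Within the data shown here, in an assay for inhibition of Nitric oxide synthase, inducible (Homo sapiens), read by scintillation counting, with a stated time of 30 min, tested at 1 mM (a higher number here means more inhibition at the concentration tested (going by the name of the read-out), a lower number less inhibition), compound 1 gives 20.7%, the highest of the two numbers measured so far. Compound 2 gives 18.3%, and the step of a number 2.4 percentage points lower from compound 1 to compound 2 (within the scatter) lies within the scatter, so the two compounds cannot be told apart on these numbers.

Compound 3 `CNC(=S)NCCC(O)c1cc(Cl)ccc1N` differs from compound 1 in one place: chloro in place of hydrogen on an aromatic carbon. Among the measured compounds shown here, the only measured step, a number 2.4 percentage points lower from compound 1 to compound 2 (within the scatter), concerns an exchange on the amine nitrogen, not the aromatic ring, and it was within the scatter; no measured pair speaks to a substituent on the ring. The expectation therefore rests on compound 1 alone, and for compound 3 the expected step is a number 1.3 percentage points higher from compound 1 to compound 3 (within the scatter), no change beyond the scatter in either direction. The estimate for compound 3 in this assay is 22%, expected to fall between 8% and 38%.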

Compound 3, a percentage reported as inhibition, at one concentration (the size of the read-out at that concentration, not a potency): 22.1%
The estimate for compound 3 lay 0.1 percentage points below the measured number; measured number inside the range.
By their numbers in this assay, from the lowest: compounds 2, 1 and 3 (each within the scatter of the next).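

In this assay, among these compounds, the step for chloro in place of hydrogen, a number 1.4 percentage points higher from compound 1 to compound 3 (within the scatter), is the first measured change on the ring, at the aromatic carbon para to an amino group. It shows that this single chlorine atom leaves the number within the scatter, so on this read-out compound 3 cannot be told apart from compound 1, just as the earlier exchange on the amine nitrogen could not separate compound 1 from compound 2. No measurement shown here offers an explanation for this result.

From the compounds shown here alone, whether a larger or different group at this carbon, such as methoxy, trifluoromethyl or a carboxylic acid, would move the number beyond the scatter remains open. So does the effect of chloro on the other aromatic carbons of the ring.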